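The compounds below may be only part of what the source reports. "The series", "measured", "known", "first", "only" and "open" are said of these compounds alone.

For the measured compounds named here, compound 2 `Cn1ccc2cc(-c3ccc4oc(N5CCCC5)nc4c3)ccc21` gives 674 nM in an assay on HEK293 cells for inhibition of Fatty-acid amide hydrolase 1 (Homo sapiens), read by fluorescence (a higher number here means a weaker inhibitor, a lower number a stronger inhibitor), the highest of the two numbers measured so far. Compound 1 `Cn1ccc2cc(-c3ccc4oc(Nc5ccc(F)cc5)nc4c3)ccc21` gives 99 nM in this assay; the step of a 6.8-fold higher number from compound 1 to compound 2 (0.83 log units; beyond the scatter) records what separates them, namely pyrrolidin-1-yl in place of (4-fluorophenyl)amino on an aromatic carbon of the shared core. Compound 3 `Cn1ccc2cc(-c3ccc4oc(N5CCn6cccc6C5)nc4c3)ccc21` has not yet been measured. Its difference from compound 2 is a group of 9 heavy atoms (7 carbon, 2 nitrogen; one five-membered aromatic ring with 1 hetero atom, one six-membered non-aromatic ring with 2 hetero atoms) in place of a group of 5 heavy atoms (4 carbon, 1 nitrogen; one five-membered non-aromatic ring with 1 hetero atom), on an aromatic carbon. Going by the values given here, no measured step covers this exact exchange, so the single step from compound 1 to compound 2 is the only guide. It shows that the group on this carbon shifts the number well beyond the scatter, and that the saturated five-membered ring gave the higher number of the two. The incoming group brings an aromatic ring back into this position, which makes a move toward the number of compound 1 plausible, though far from certain. Compound 3 is therefore expected to give 400 nM in this assay, with a likely range from 120 nM to 1500 nM, which would correspond to the estimated step of a 1.7-fold lower number from compound 2 to compound 3 (0.23 log units; within the scatter).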

Compound 3, half-maximal inhibitory concentration: 42 nM
Compound 3: middle estimate off by 9.5-fold (0.98 log units), on the high side, and the stated range ends above it.
By their numbers in this assay, from the lowest: compound 3; then compound 1; then compound 2.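

At this carbon, next to the ring nitrogen and the ring oxygen, a group joined through a ring nitrogen can give a strong inhibitor: in this assay the fused two-ring group brings a 16-fold lower number from compound 2 to compound 3 (1.21 log units; beyond the scatter) and so removes the weakness seen with pyrrolidin-1-yl. The same group also goes beyond the (4-fluorophenyl)amino group of the first compound, with a 2.4-fold lower number from compound 1 to compound 3 (0.37 log units; beyond the scatter) in this assay as the step. A ring nitrogen joined directly to this carbon, as in compound 2 and compound 3, therefore does not by itself bring the higher number, and what the group carries beyond that nitrogen matters greatly. No outside measurement bears on what lies behind these steps.

The new group differs from pyrrolidin-1-yl in both its size and its five-membered aromatic ring, so these compounds cannot show which of the two features accounts for the step. A plain piperidin-1-yl or a morpholin-4-yl group on the same carbon of the shared core would help to separate ring size from the added aromatic ring.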